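This account rests on a few compounds, and the source may have more. Where it says the series, first, only, none or still open, it means among the compounds named here.

Measured so far:
Compound 1 `O=S(=O)(c1ccccc1Cl)n1ccc2c(N3CCNCC3)cccc21` gives 0.398 nM in an assay on HeLa cells for displacement of a labelled ligand from 5-hydroxytryptamine receptor 6 (Homo sapiens); a lower number here means a stronger inhibitor, a higher number a weaker inhibitor.
Compound 2 `O=S(=O)(c1ccccc1)n1ccc2c(N3CCNCC3)c(Cl)ccc21` gives 1.59 nM in this assay.

For the measured compounds named here, compound 2 stands at the higher of the two numbers; its only neighbour, compound 1, sits at a lower number, and the gap between them lies beyond the usual scatter. The two compounds differ in two places at once, so what that gap shows for either change alone cannot be separated.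

The step to compound 3 `O=S(=O)(c1ccccc1Cl)n1ccc2c(N3CCNCC3)c(Cl)ccc21` alters compound 2 in one place: chloro in place of hydrogen on an aromatic carbon — chloro in place of hydrogen on an aromatic carbon, which read one bond further out is phenyl to 2-chlorophenyl. Going by the values given here, no single-change step between measured compounds is available to set its size. Among the compounds with values here, what can be said is that compound 1, the one carrying the 2-chlorophenyl group, has the lowest number seen, with 0.398 nM. On that ground the step is expected to run toward a lower number and to be of moderate size, a 2.3-fold lower number from compound 2 to compound 3 (0.36 log units; beyond the scatter). The estimate for compound 3 is 0.7 nM, with a range from 0.25 nM to 2 nM.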

Compound 3, inhibition constant: 1 nM
Beside the measured number, compound 3's estimate is 1.4-fold (0.15 log units) below it; the measured number falls inside the stated range.
By their numbers in this assay, from the lowest: compound 1; then compounds 3 and 2 (each within the scatter of the next).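

In this assay, the 2-chlorophenyl group in place of phenyl, with the chloro on the core present in both compounds, gives a 1.6-fold lower number from compound 2 to compound 3 (0.20 log units; within the scatter), so on this core the added chloro ortho to a large group produces no difference that can be told from the scatter. The other single change, chloro in place of hydrogen on an aromatic carbon of the core with the 2-chlorophenyl group held fixed, gives a 2.5-fold higher number from compound 1 to compound 3 (0.40 log units; beyond the scatter), and this is the only step shown that lies beyond the scatter, which separates for the first time the two changes that the earlier pair carried together. Nothing shown gives a reason for either step.

Whether the change from phenyl to 2-chlorophenyl would also stay within the scatter on a core without the chloro remains open, as the compounds shown offer no such pair. Also open, on these data alone, is how other groups would read at either place, such as a methyl, a methoxy, a nitrile or an amine in place of chloro.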